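Swapping a ring for isopropoxy on the shared core

The source may report more compounds than this note shows. Statements on the series, on what has been measured and on what is new or still open speak of the compounds shown alone.

Measured in a functional assay on HepG2 cells (Homo sapiens) for inhibition, read by MTT assay, with a stated time of 72 h; a lower number here means a stronger inhibitor, a higher number a weaker inhibitor:
- compound 1 `CC(C)(C)n1cc2c(n1)C(=O)CC1(CCN(C(=O)c3cc(-c4ccc(N)cc4)nc4ccccc34)CC1)O2` gives 630 nM
- compound 2 `CC(C)(C)n1cc2c(n1)C(=O)CC1(CCN(C(=O)c3cc(-c4ccncc4)nc4ccccc34)CC1)O2` gives 380 nM

Within the data shown here, these are the only two measured compounds, and compound 2 stands within the usual scatter of compound 1. Compound 3 `CC(C)Oc1cc(C(=O)N2CCC3(CC2)CC(=O)c2nn(C(C)(C)C)cc2O3)c2ccccc2n1` is still unmeasured. It differs from compound 2 as follows: isopropoxy in place of pyridin-4-yl on an aromatic carbon, with isopropoxy in place of pyridin-4-yl on an aromatic carbon. Among the measured compounds shown here, the one measured step at this carbon is a 1.7-fold lower number from compound 1 to compound 2 (0.22 log units; within the scatter), which exchanged 4-aminophenyl for pyridin-4-yl. That step links two ring groups, whereas isopropoxy has no ring, so it is only a loose guide. On that evidence, no step beyond the scatter is expected in this assay, and no direction can be favoured with confidence. The expected step is a 1.3-fold higher number from compound 2 to compound 3 (0.10 log units; within the scatter) and it carries wide uncertainty. Compound 3 is estimated at 480 nM, within an expected range of 160 nM to 1500 nM once measured.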

Compound 3, half-maximal inhibitory concentration: 3150 nM
Compound 3: the middle estimate sits 6.6-fold (0.82 log units) below what was measured; the measured number lies above the stated range.
By their numbers in this assay, from the lowest: compounds 2 and 1 (each within the scatter of the next); then compound 3.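

In this assay, this position on the shared core proves sensitive to what it carries. Pyridin-4-yl and 4-aminophenyl gave values within the scatter of each other, yet isopropoxy, the one group here without a ring, brings an 8.3-fold higher number from compound 2 to compound 3 (0.92 log units; beyond the scatter) and a 5.0-fold higher number from compound 1 to compound 3 (0.70 log units; beyond the scatter) in the same assay. Among these three compounds the two with a ring group at this carbon have the lower numbers and none goes against that, but no measurement available here explains the difference.

Isopropoxy differs from both ring groups in two ways at once, having no ring and having an oxygen attached to the aromatic carbon, and the compounds shown do not separate the two. Going by these compounds, it remains open whether a plain phenyl ring, a methoxy group or a longer chain such as butoxy would land nearer compound 2 or compound 3.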